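The source may hold more compounds than are shown below. What is called first, only, known or untested is meant among the compounds shown, and "the series" means these compounds.

Working notes on the series sharing one core. Compound 1 `Cn1c(Cc2nn(C)c(=O)c3ccccc23)nnc1S(=O)(=O)CCCCCCCC(=O)Nc1ccc(Br)cc1Br` carries the long sulfone-linked chain ending in a dibromophenyl amide, and in an assay on isolated protein (Mus musculus) for inhibition of IL15-IL15 receptor (Homo sapiens), read by resazurin assay, with stated times of 30 min and 2.5 days (a lower number here means a stronger inhibitor, a higher number a weaker inhibitor), compound 1 gives 1400 nM. Compound 3 `Cn1c(Cc2nn(C)c(=O)c3ccccc23)nnc1SCCCCCCCC(=O)Nc1ccc(O)cc1O` keeps a long chain but with a thioether link and a dihydroxyphenyl amide, and in this assay compound 3 gives 17000 nM. Within the data shown here, compound 2 `Cn1c(Cc2nn(C)c(=O)c3ccccc23)nnc1SCC(=O)Nc1ccc(I)cc1` has the short thioether-linked chain with a 4-iodophenyl amide; in this assay compound 2 is recorded as "not active" (no number reported), so no number stands for it, and no step between measured compounds is available to set a scale.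

Compound 4 `Cn1c(Cc2nn(C)c(=O)c3ccccc23)nnc1SCC(=O)Nc1ccc(O)cc1` is compound 2 with hydroxy in place of iodo on an aromatic carbon. Among the measured compounds shown here, no measured pair shows this change, so its size cannot be taken from the data. What the two longer-chain compounds show is that the whole set sits at weak inhibition, and the short chain of compound 2 gave no measurable number. Compound 4 is therefore expected to remain weak, with an estimated value of 30000 nM in this assay, within a range of 8000 nM to 100000 nM, and a real chance that again only a limit is reported.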

Compound 4, half-maximal inhibitory concentration: "not active" (no number reported)
No number was reported for compound 4; no gap can be computed for the estimate.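

Compound 2 and compound 4 are both recorded as not active in this assay, without a number, so no step can be read between them. Nothing shown bears on this result. The compounds shown leave open whether any short-chain thioether amide reaches a measurable value.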